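This account rests on a few compounds, and the source may have more. Where it says the series, first, only, none or still open, it means among the compounds named here.

Measured so far in an ADME assay on PBMC cells (Homo sapiens) for cytotoxicity; a higher number here means that more compound is tolerated, a lower number that less compound is tolerated:

Compound 1 `Cc1ccnc(OC(c2ccc(C(F)(F)F)cc2)C2CCN(C(C)CCNC(=O)c3c(Cl)cncc3Cl)CC2)c1` gives 33600 nM.
Compound 2 `CCO/N=C(/c1ccc(Br)cc1)C1CCN(C(C)CCN(C)C(=O)c2c(C)cc[n+]([O-])c2C)CC1` gives > 182000 nM, which is a limit of the assay and not a number.
Compound 3 `CC(CCNC(=O)c1c(Cl)cncc1Cl)N1CCC(C(O)c2ccc(Br)cc2)CC1` gives 198000 nM.

Among the two numbers in hand, compound 1 stands lowest: compound 3 is tolerated at a higher concentration, and the gap between compound 3 and compound 1 lies beyond the usual scatter of this assay. Compound 2 sits at a limit, so its place relative to the others cannot be fixed. Going by the values given here, all three share the same core; no pair of them differs in only one place, so no single change can yet be tied to a measured step in this assay.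

Compound 4 `CC(CCNC(=O)c1c(Cl)cncc1Cl)N1CCC(C(Oc2ccccc2C(F)(F)F)c2ccc(C(F)(F)F)cc2)CC1` is the next compound, not yet measured. It differs from compound 1 in one place:

2-(trifluoromethyl)phenyl in place of 4-methylpyridin-2-yl on an oxygen on a saturated carbon

Among the compounds with values here, with no measured step of this kind to lean on, the expected size of the step from compound 1 to compound 4 in this assay is small and most likely within the scatter, with the wider side of the range opening toward a lower number. The estimate for compound 4 is 25000 nM, with a range from 8000 nM to 80000 nM, a step of a 1.3-fold lower number from compound 1 to compound 4 (0.13 log units; within the scatter) from compound 1 that is expected rather than known.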

Compound 4, half-maximal cytotoxic concentration: 12500 nM
Compound 4: middle estimate off by 2.0-fold (0.30 log units), on the high side, and the stated range covers the measured number.
By their numbers in this assay, from the lowest: compound 4; then compound 1; then compound 3.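

In this assay, going by these compounds alone, the group on the oxygen now has its first measured step, which the earlier compounds could not give since no pair of them differed in one place: 2-(trifluoromethyl)phenyl in place of 4-methylpyridin-2-yl brings a 2.7-fold lower number from compound 1 to compound 4 (0.43 log units; beyond the scatter), so this position is not silent for cytotoxicity. The change swaps a ring with one nitrogen and one hydrogen-bond acceptor for a carbon-only ring with more heavy atoms and no hydrogen-bond acceptor, and here that swap goes with less compound being tolerated. This is a single pair and a modest step, so it marks a direction for this one swap and sets no rule for the position.

On these data alone, the swap changes the ring and its substituent together, so it remains open whether the ring nitrogen, the trifluoromethyl group or the loss of the methyl group carries the step, and how a plain phenyl, or a ring bearing an amine or a carboxylic acid, would read in this assay. Nothing in the evidence at hand bears on why the number moved.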